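The source may hold more compounds than are shown below. What is called first, only, known or untested is meant among the compounds shown, and "the series" means these compounds.

Among the compounds with values here, in a functional assay on MCF7 cells (Homo sapiens) for antiproliferative activity, read by MTT assay, with a stated time of 72 h (a lower number here means a stronger inhibitor, a higher number a weaker inhibitor), compound 2 `COc1cc(-n2cnc3ccc(-c4cc(F)ccc4F)cc32)cc(OC)c1OC` gives 6420 nM, the highest of the two numbers measured so far. Its nearest neighbour is compound 1 `COc1cc(-n2cnc3ccc(-c4cccc(N)c4)cc32)cc(OC)c1OC`, which in this assay gives 180 nM; the measured step is a 36-fold higher number from compound 1 to compound 2 (1.55 log units; beyond the scatter), with 2,5-difluorophenyl in place of 3-aminophenyl on an aromatic carbon. Compound 3 `COc1cc(-n2cnc3ccc(-c4ccccc4)cc32)cc(OC)c1OC` is the next member of the series: phenyl in place of 2,5-difluorophenyl on an aromatic carbon. Within the data shown here, only that single large step bears on this change, and it does not isolate the phenyl itself, since phenyl carries neither the fluorines of compound 2 nor the amino group of compound 1. Compound 3 is expected to land between the two, nearer compound 2, with a step in this assay estimated at a 3.2-fold lower number from compound 2 to compound 3 (0.51 log units; beyond the scatter), toward a lower number. Compound 3 is estimated at 2000 nM, within a range from 600 nM to 7000 nM.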

Compound 3, half-maximal inhibitory concentration: 2290 nM
Compound 3: the middle estimate sits 1.1-fold (0.06 log units) below what was measured; the range from low to high includes it.
By their numbers in this assay, from the lowest: compound 1; then compound 3; then compound 2.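

The earlier step from the 3-aminophenyl compound to the 2,5-difluorophenyl compound could not be divided, but the plain phenyl now splits it into two parts. Replacing 2,5-difluorophenyl with phenyl gives, in this assay, a 2.8-fold lower number from compound 2 to compound 3 (0.45 log units; beyond the scatter), so the two fluorines do not improve on the unsubstituted ring at this position on the shared core. The larger part belongs to the amino group: replacing it with hydrogen gives a 13-fold higher number from compound 1 to compound 3 (1.10 log units; beyond the scatter), which makes the amino group, among these three substituent patterns, the one feature tied to a large gain.

Nothing shown here explains either step. Going by these compounds, it remains open whether a hydroxyl group, a methylamino group or an aminomethyl chain would match the amino group, and whether a single fluorine would produce the same loss as the pair.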